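The source may report more compounds than this note shows. Statements on the series, on what has been measured and on what is new or still open speak of the compounds shown alone.

In a functional assay on HepG2 cells (Homo sapiens) for cytotoxicity, read by MTT assay, with a stated time of 72 h (a lower number here means a stronger inhibitor, a higher number a weaker inhibitor), compound 1 (`Nc1ccccc1NC(=O)c1ccc(NC(=O)NCc2cccnc2)cc1`) gives 5100 nM and compound 2 (`Nc1ccccc1NC(=O)c1ccc(NC(=O)NCc2ccc(F)nc2)cc1`) gives 13000 nM. Compound 2 therefore holds the higher of the two numbers, and its gap to compound 1 lies beyond the scatter.

The next structure is compound 3 (`Nc1ccc(CNC(=O)Nc2ccc(C(=O)Nc3ccccc3N)cc2)cn1`), with amino in place of fluoro on an aromatic carbon, turning 6-fluoropyridin-3-yl into 6-aminopyridin-3-yl: amino in place of fluoro on an aromatic carbon. The change sits next to the ring nitrogen, para to a large group.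

Within the data shown here, only one measured step bears on it: a 2.5-fold higher number from compound 1 to compound 2 (0.41 log units; beyond the scatter), a modest step with fluoro in place of hydrogen on an aromatic carbon. Among the measured compounds shown here, no amino compound has been measured, so the amino effect itself remains unknown. Compound 1 stands at 5100 nM without the fluoro, so a modest move to a lower number in this assay is expected once the fluoro leaves, though the direction is not secure. The expected change is a 2.4-fold lower number from compound 2 to compound 3 (0.37 log units; beyond the scatter). For compound 3 the estimated value is 5500 nM, with an expected range of 2000 nM to 15000 nM.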

Compound 3, half-maximal inhibitory concentration: 3100 nM
Compound 3: the middle estimate sits 1.8-fold (0.25 log units) above what was measured, within the range that was stated.
By their numbers in this assay, from the lowest: compounds 3 and 1 (each within the scatter of the next); then compound 2.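

Fluoro is the only one of the three groups at this position that moves the number beyond the scatter: in this assay, amino in place of fluoro on the aromatic carbon next to the ring nitrogen gives a 4.2-fold lower number from compound 2 to compound 3 (0.62 log units; beyond the scatter), a step that undoes the rise seen with fluoro. Amino in place of hydrogen at the same carbon gives a 1.6-fold lower number from compound 1 to compound 3 (0.22 log units; within the scatter), so in this assay the data do not separate the amino group from hydrogen, and the earlier pair could not show that a substituent here can leave the number unmoved. The data offer nothing that accounts for the gap between fluoro and the other two groups.

Still open, as far as these compounds go, is whether chloro, methoxy or dimethylamino on this same aromatic carbon would fall with fluoro or with amino and hydrogen, since three groups at one position set no trend. Also open, from the compounds shown here alone, is whether the amino group would leave the number equally unmoved on another carbon of the six-membered ring, or with a longer chain in place of the methyl link to the urea.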